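This account rests on a few compounds, and the source may have more. Where it says the series, first, only, none or still open, it means among the compounds named here.

Going by the values given here, the three compounds measured so far share one core, and differ only in what sits on an aromatic carbon of the 1H-indazol-1-yl group. Compound 1 `O=C(Nc1ccc(-n2ncc3c(Br)cccc32)cc1)Nc1ccc(Cl)c(C(F)(F)F)c1` carries bromo there; in a functional assay on SGC-7901 cells (Homo sapiens) for cytotoxicity, read by MTT assay, with a stated time of 72 h (on this read-out higher numbers stand for weaker inhibition and lower numbers for stronger inhibition), compound 1 gives 16600 nM. Compound 2 `O=C(Nc1ccc(-n2ncc3c(F)cccc32)cc1)Nc1ccc(Cl)c(C(F)(F)F)c1` carries fluoro there; in this assay compound 2 gives 32000 nM. The step of a 1.9-fold higher number from compound 1 to compound 2 (0.29 log units; within the scatter) is small. Compound 3 `O=C(Nc1ccc(-n2ncc3ccccc32)cc1)Nc1ccc(Cl)c(C(F)(F)F)c1` carries hydrogen there. In this assay compound 3 reaches only the limit > 32000 nM, which is a boundary of the measurement and not a number. The steps of an at least 1.9-fold higher number from compound 1 to compound 3 (0.28 log units; that floor lies within the scatter) and a number no lower from compound 2 to compound 3 (the limit leaves the size open) therefore have no firm size, since one of the three values sits at that limit (the limit of > 32000 nM in this assay, at which 1 of the 3 values shown sits). Compound 3 stands at the weak end of what has been measured. Compound 4 `O=C(Nc1ccc(-n2ncc3cnccc32)cc1)Nc1ccc(Cl)c(C(F)(F)F)c1` differs from compound 3 by a group of 9 heavy atoms (6 carbon, 3 nitrogen; one five-membered aromatic ring with 2 hetero atoms, one six-membered aromatic ring with 1 hetero atom) in place of a group of 9 heavy atoms (7 carbon, 2 nitrogen; one five-membered aromatic ring with 2 hetero atoms, one six-membered aromatic ring of carbon only), on an aromatic carbon. Among the compounds with values here, none of the measured steps covers an exchange of this kind, and all of them are small or bounded. The step that the limit leaves unreadable from compound 3 to compound 4 is expected to stay within the scatter. Compound 4 is estimated in this assay at 40000 nM, within a range from 15000 nM to 100000 nM, and is expected most likely to be reported again as a limit.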

Compound 4, half-maximal inhibitory concentration: 22600 nM
Estimate against measurement, compound 4: 1.8-fold (0.25 log units) above, and the stated range covers the measured number.
By their numbers in this assay, from the lowest: compounds 1, 4 and 2 (each within the scatter of the next).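

In this assay compound 4 shows that a hetero atom in the six-membered aromatic ring of this group, with no halogen on the group at all, gives a value that cannot be told apart from those of the two halogen compounds: a 1.4-fold lower number from compound 2 to compound 4 (0.15 log units; within the scatter), and a 1.4-fold higher number from compound 1 to compound 4 (0.13 log units; within the scatter). Set against compound 3, the change reads an at least 1.4-fold lower number from compound 3 to compound 4 (0.15 log units; that floor lies within the scatter), so this exchange is the first in the series with a measured value on the side of the ring nitrogen. Compound 3 stands at a limit, so that step gives only a floor and no firm size: the limit of > 32000 nM in this assay, at which 1 of the 4 values shown sits.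

The compounds shown leave open how an amine or a methoxy group in place of the bromo of compound 1 would read in this assay. They also leave open whether the ring nitrogen would read the same with a bromo group on the same ring.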